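The source may report more compounds than this note shows. Statements on the series, on what has been measured and on what is new or still open speak of the compounds shown alone.

Measured compounds in a functional assay on A549 cells (Homo sapiens) for antiproliferative activity, read by MTT assay, with a stated time of 72 h; on this read-out higher numbers stand for weaker inhibition and lower numbers for stronger inhibition:

- compound 1 `O=C1COc2ccc(-c3cnc(Cl)c(NS(=O)(=O)c4ccc(F)cc4)c3)cc2N1C1CCCCC1` gives 37900 nM
- compound 2 `COc1ncc(-c2ccc3c(c2)N(C2CCCCC2)C(=O)CO3)cc1NS(=O)(=O)c1ccc(F)cc1` gives 24600 nM
- compound 3 `COc1cccc(N2C(=O)COc3ccc(-c4cccc(NS(=O)(=O)c5ccc(F)cc5)c4)cc32)c1` reaches only the assay limit, > 40000 nM

Compound 1 stands at the highest of the two numbers in this assay; its nearest neighbour is compound 2, with a 1.5-fold lower number from compound 1 to compound 2 (0.19 log units; within the scatter), a change of methoxy in place of chloro on an aromatic carbon. Compound 3 sits at the limit of > 40000 nM in this assay, at which 1 of the 3 values shown sits; of that compound only the limit is known.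

Compound 4 `O=C1COc2ccc(-c3cnc(Cl)c(NS(=O)(=O)c4ccc(F)cc4)c3)cc2N1C1CC1` is the next member. It differs from compound 1 by cyclopropyl in place of cyclohexyl on an amide-type nitrogen in a ring. Within the data shown here, no measured step in this assay changes the group on the amide-type nitrogen in a ring: the single step, from compound 1 to compound 2, touches a different place and stays within the scatter. Among the measured compounds shown here, compound 3 carries another group at that nitrogen but differs from compound 1 in more than one place, so it gives no single step to lean on.

With nothing to point the other way, no step beyond the scatter is expected in this assay for compound 4. Compound 4 is estimated at 40000 nM, with a range from 15000 nM to 110000 nM. The expected step is a 1.1-fold higher number from compound 1 to compound 4 (0.02 log units; within the scatter).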

Compound 4, half-maximal inhibitory concentration: 4330 nM
Beside the measured number, compound 4's estimate is 9.2-fold (0.97 log units) above it; measured number below the stated range.
By their numbers in this assay, from the lowest: compound 4; then compounds 2 and 1 (each within the scatter of the next). At a limit, above all of these: compound 3.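

In this assay, among these compounds, the group on the amide-type nitrogen in a ring proves to be a place where a single change matters: cyclopropyl in place of cyclohexyl gives an 8.8-fold lower number from compound 1 to compound 4 (0.94 log units; beyond the scatter) and so moves the number beyond the scatter, which the one earlier step, made at another place, did not do. Of the two groups compared directly at this nitrogen, the smaller ring, with 3 heavy atoms against 6, gives the lower number. Compound 3 carries another group at that nitrogen but differs from compound 1 in more than one place, so no step can be read from it, and its value is only a limit: the limit of > 40000 nM in this assay, at which 1 of the 4 values shown sits.

Two groups cannot show whether the number follows ring size; cyclopentyl, isopropyl or a chain ending in an amine at this nitrogen would test that. On these data alone, whether the step holds with methoxy in place of chloro also stays open.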